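Replacing the piperazine of compound 2: mean residence time in mice

The source may report more compounds than this note shows. Statements on the series, on what has been measured and on what is new or still open speak of the compounds shown alone.

Compound 2 `Cc1cn(-c2cc(NC(=O)c3ccc(C)c(Oc4ccccc4)c3)cc(N3CCN(C)CC3)c2)cn1` stands highest of the three measured numbers in an ADME assay on the whole organism (Mus musculus, strain CD1), read by LC-MS, using cassette dosing, with a stated time of 24 h, at a dose of 0.4 mg/kg by the intravenous route (a lower number here means that the compound disappears faster, a higher number that the compound lasts longer), where compound 2 gives 8.98 h. Compound 1 `Cc1cn(-c2cc(NC(=O)c3ccc(C)c(Oc4ccccc4)c3)cc(C(F)(F)F)c2)cn1` gives 2.27 h, and compound 3 `Cc1cn(-c2cc(NC(=O)c3ccc(C)c(Oc4cccc5ccncc45)c3)cc(N3CCN(C)CC3)c2)cn1` gives 2.3 h. Both measured steps pass through compound 2: a 4.0-fold higher number from compound 1 to compound 2 (0.60 log units; beyond the scatter), and a 3.9-fold lower number from compound 2 to compound 3 (0.59 log units; beyond the scatter).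

Compound 4 `Cc1cn(-c2cc(CN3CCC[C@H](N)C3)cc(NC(=O)c3ccc(C)c(Oc4ccccc4)c3)c2)cn1` differs from compound 2 in one place: (3-aminopiperidin-1-yl)methyl in place of 4-methylpiperazin-1-yl on an aromatic carbon. Going by the values given here, neither measured step exchanges one of these two groups for the other, so neither bears on the change directly; they show only that a single change on the same aromatic carbon, or on the oxygen-linked ring, moved this assay by a modest amount, and that compound 2 alone reached the high number. A modest step down, a 2.2-fold lower number from compound 2 to compound 4 (0.35 log units; beyond the scatter), is expected, because a 4.0-fold higher number from compound 1 to compound 2 (0.60 log units; beyond the scatter) ties the high number to the very group that now leaves. The estimate for compound 4 is 4 h, with a range from 1.5 h to 11 h.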

Compound 4, mean residence time: 34.9 h
Beside the measured number, compound 4's estimate is 8.7-fold (0.94 log units) below it; measured number outside the range, above it.
By their numbers in this assay, from the lowest: compounds 1 and 3 (each within the scatter of the next); then compound 2; then compound 4.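

In this assay, the aromatic carbon that carries the 4-methylpiperazin-1-yl group of compound 2 proves not to depend on that group for a high number: (3-aminopiperidin-1-yl)methyl there gives a 3.9-fold higher number from compound 2 to compound 4 (0.59 log units; beyond the scatter). Set against trifluoromethyl on the same carbon, the new group gives a 15-fold higher number from compound 1 to compound 4 (1.19 log units; beyond the scatter), the only large step shown at this position. No measurement at hand speaks to the reason for the rise.

Which part of the entering group goes with the rise stays open, since the compounds shown do not separate the methyl link from the amine on the ring; a (4-methylpiperazin-1-yl)methyl group or a plain aminomethyl group on this carbon would divide the two. Also open, on these data alone, is whether the rise holds with isoquinolin-8-yl on the oxygen, the change that gave a 3.9-fold lower number from compound 2 to compound 3 (0.59 log units; beyond the scatter).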